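The compounds below may be only part of what the source reports. "The series", "measured", "known", "first", "only" and "open" are said of these compounds alone.

Measured so far in an assay on cells for agonist activity at Bombesin receptor subtype-3 (Mus musculus), read by HTRF and inositol phosphate accumulation, with a stated time of 1 h; a lower number here means that less compound is needed, a higher number that more compound is needed for the effect:
- compound 1 `COC(=O)c1ccccc1-c1ccc(CCc2ncc(CC(C)(C)C)n2CC(=O)O)cc1`: 694 nM
- compound 2 `COC(=O)c1c(F)cccc1-c1ccc(CCc2ncc(CC(C)(C)C)n2CCC(=O)O)cc1`: 3 nM

Compound 2 stands at the lowest of the two numbers in this assay; its nearest neighbour, compound 1, gives a value higher by a margin well beyond the scatter. Going by the values given here, compound 1 and compound 2 differ in more than one place, so no single step between them is counted, and their two values are simply noted as they stand.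

Compound 3 `COC(=O)c1c(F)cccc1-c1ccc(CCc2ncc(CC(C)(C)C)n2Cc2ccc(C(=O)O)cc2)cc1` is not yet measured. It differs from compound 2 in one place: 4-carboxyphenyl in place of carboxymethyl on a saturated chain carbon bound to an aromatic nitrogen. The acid group is kept, but it now sits on an aromatic ring rather than at the end of a short chain, and the count of heavy atoms on that arm grows.

There is no measured step of this kind in the series, so the direction of the change can only be expected. A step in this assay from compound 2 to compound 3 of a 5.0-fold higher number from compound 2 to compound 3 (0.70 log units; beyond the scatter) is expected, towards a higher number, beyond the scatter but modest. Compound 3 is estimated at 15 nM, with a range from 3 nM to 80 nM.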

Compound 3, half-maximal effective concentration: 5 nM
Compound 3: the middle estimate sits 3.0-fold (0.48 log units) above what was measured, and the stated range covers the measured number.
By their numbers in this assay, from the lowest: compounds 2 and 3 (each within the scatter of the next); then compound 1.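

In this assay, 4-carboxyphenyl in place of carboxymethyl on a saturated chain carbon bound to an aromatic nitrogen gives a 1.7-fold higher number from compound 2 to compound 3 (0.22 log units; within the scatter) and so leaves the reading unchanged within the scatter. This position therefore accepts an arm that grows from 4 to 9 heavy atoms and gains a six-membered aromatic ring of carbon only, and the acid group need not stand at the end of a short chain for the value to stay in this range, although this rests on one pair and is no trend. No measured evidence bears on why the two arms read alike.

Whether the carboxylic acid itself is needed on this arm remains open, as the compounds shown all carry one and none has a primary amide, a hydroxymethyl or an amine in its place. Also open is how far the arm can grow, since a longer chain between the aromatic ring and the acid, or a larger ring system at this place, lies outside the compounds shown.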